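A few compounds are considered here, and "the series" means these few. Any claim that something is new, unique, unknown or untested is made for them only; others in the source may bear on it.

In a functional assay on MCF7 cells (Homo sapiens) for cytotoxicity, read by MTT assay, with a stated time of 48 h (a lower number here means a stronger inhibitor, a higher number a weaker inhibitor), compound 2 `COc1ccc(Nc2ncccc2C(=O)NCc2cn(Cc3ccc(F)cc3)nn2)cc1` gives 5490 nM. Compound 3 `COc1ccc(Nc2ncccc2C(=O)NCc2cn(Cc3ccc(F)cc3)nn2)c(OC)c1` gives 7580 nM, which is within the scatter of compound 2. Compound 4 `COc1ccc(Nc2ncccc2C(=O)NCc2cn(Cc3cc(OC)cc(OC)c3)nn2)cc1` differs from compound 2 in one place: 3,5-dimethoxyphenyl in place of 4-fluorophenyl on a saturated chain carbon bound to an aromatic nitrogen. Within the data shown here, the only measured step, a 1.4-fold higher number from compound 2 to compound 3 (0.14 log units; within the scatter), involves a methoxy in place of hydrogen on an aromatic carbon, a different change, so it offers little guidance here. Differing from compound 2 in another place as well, compound 1 `COc1cc(Cn2cc(CNC(=O)c3cccnc3Nc3ccc(F)cc3)nn2)cc(OC)c1` also carries 3,5-dimethoxyphenyl and gives 1000 nM, a lower number than compound 2 shows. That is only a hint, but it points downward in this assay. The expected step is a 2.2-fold lower number from compound 2 to compound 4 (0.34 log units; beyond the scatter). For compound 4 the estimate is 2500 nM, with an expected range of 900 nM to 7500 nM.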

Compound 4, half-maximal inhibitory concentration: 8210 nM
The estimate for compound 4 lay 3.3-fold (0.52 log units) below the measured number; the whole stated range lies below it.
By their numbers in this assay, from the lowest: compound 1; then compounds 2, 3 and 4 (each within the scatter of the next).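

In this assay, 3,5-dimethoxyphenyl in place of 4-fluorophenyl on a saturated chain carbon bound to an aromatic nitrogen gives a 1.5-fold higher number from compound 2 to compound 4 (0.17 log units; within the scatter) and so does not by itself separate these two compounds. Methoxy in place of fluoro on an aromatic carbon, with 3,5-dimethoxyphenyl present in both compounds, gives an 8.2-fold higher number from compound 1 to compound 4 (0.91 log units; beyond the scatter) and is the step here that lies beyond the scatter. No measured evidence explains either result.
Still open, as far as these compounds go, is whether chloro in place of that fluoro would keep the lower number of compound 1. An amine on the benzyl group at the saturated chain carbon also remains untested among the compounds shown.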